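This account rests on a few compounds, and the source may have more. Where it says the series, first, only, none or still open, it means among the compounds named here.

Working notes on the series. For the measured compounds named here, in a functional assay on MDA-MB-231 cells (Homo sapiens) for antiproliferative activity, read by MTT assay, with a stated time of 48 h (on this read-out higher numbers stand for weaker inhibition and lower numbers for stronger inhibition), compound 1 (`COc1ccc(/C=C/C(=O)Nc2cc3c(Nc4ccc(Cl)c(Cl)c4)ncnc3s2)cc1`) gives 16600 nM, the higher of the two numbers so far. Compound 2 (`N#Cc1cccc(Nc2ncnc3cc(NC(=O)/C=C/c4ccccc4)sc23)c1`) gives 1040 nM, a gap beyond the scatter. Compound 1 is therefore the weaker inhibitor of the pair.

Compound 3 (`O=C(/C=C/c1ccccc1)Nc1cc2c(Nc3ccc(Cl)c(Cl)c3)ncnc2s1`) departs from compound 1 at one place: hydrogen in place of methoxy on an aromatic carbon. This puts hydrogen in place of methoxy on an aromatic carbon, para to a large group, turning 4-methoxyphenyl into phenyl.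

Going by the values given here, no measured pair isolates this change, so the expectation rests on thin support. Compound 2, which also carries no methoxy, stands at 1040 nM, and this single value suggests a move toward stronger inhibition. The expected size is moderate, and a result within the scatter remains possible. The estimated change is a 2.8-fold lower number from compound 1 to compound 3 (0.44 log units; beyond the scatter). For compound 3 the expected value in this assay is 6000 nM, with an estimated range of 1800 nM to 20000 nM.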

Compound 3, half-maximal inhibitory concentration: 4400 nM
Compound 3: the middle estimate sits 1.4-fold (0.13 log units) above what was measured, and the stated range covers the measured number.
By their numbers in this assay, from the lowest: compound 2; then compound 3; then compound 1.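

In this assay, for the compounds shown here, the only single-place pair shows a 3.8-fold lower number from compound 1 to compound 3 (0.58 log units; beyond the scatter) on going from 4-methoxyphenyl to phenyl. Going by these compounds alone, this is the first direct reading of this position: with the rest of the structure held constant, the carbon para to a large group responds to substitution, and hydrogen there gives stronger inhibition than methoxy. No measurement bears on why the step occurs, so it stands as an observation on one pair.

On these data alone, whether any group at this carbon lowers activity, or methoxy alone does so, stays open; fluorine, hydroxy, an amine or a longer ether such as ethoxy at the same place would separate these readings. Also open, as far as these compounds go, is whether methoxy on another carbon of this ring, or the same change on a different core, gives a step of similar size.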